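Cytotoxicity of a Pyrazolo Urea Series: Swapping the Lactam Substituent

The source may report more compounds than this note shows. Statements on the series, on what has been measured and on what is new or still open speak of the compounds shown alone.

Of the compounds shown here, two from one series have been tested for toxicity. Compound 1 `O=C1CC(c2ccc(F)cn2)CN1c1cnn2c1CN(C(=O)Nc1cc(F)c(F)c(F)c1)C(C1CC1)C2` carries a pyrrolidinone bearing a fluoropyridine, and compound 2 `O=C1c2ccccc2CN1c1cnn2c1CN(C(=O)Nc1cc(F)c(F)c(F)c1)C(C1CC1)C2` carries a benzo-fused lactam on the same shared core. In a toxicity assay on HepG2 2.2.15 cells (Homo sapiens) for cytotoxicity, read by CellTiter-Glo (on this read-out higher numbers stand for lower toxicity in this test and lower numbers for higher toxicity in this test), compound 1 gives 38500 nM, and in the same test compound 2 gives 38500 nM, so the two stand level with each other and compound 2 is no more and no less toxic than compound 1 within the scatter.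

Compound 3 `Cc1cnc(C2CC(=O)N(c3cnn4c3CN(C(=O)Nc3cc(F)c(F)c(F)c3)C(C3CC3)C4)C2)s1` is not yet measured. It differs from compound 2 by the change (a group of 12 heavy atoms (8 carbon, 2 nitrogen, 1 oxygen, 1 sulfur; one five-membered non-aromatic ring with 1 hetero atom, one five-membered aromatic ring with 2 hetero atoms) in place of a group of 10 heavy atoms (8 carbon, 1 nitrogen, 1 oxygen; one five-membered non-aromatic ring with 1 hetero atom, one six-membered aromatic ring of carbon only), on an aromatic carbon). The group that enters resembles the group found in compound 1, a pyrrolidinone bearing a small aromatic ring, and compound 1 gave the same reading as compound 2.

Because compound 1 gives 38500 nM and compound 2 gives 38500 nM, the step from compound 2 to compound 3 is expected to be none beyond the scatter, that is no change at the digits printed from compound 2 to compound 3 (within the scatter). Compound 3 is therefore estimated at 38500 nM, within a range from 15000 nM to 80000 nM.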

Compound 3, half-maximal cytotoxic concentration: 96200 nM
For compound 3 the middle estimate is 2.5-fold (0.40 log units) below the measured one; measured number outside the range, above it.
By their numbers in this assay, from the lowest: compounds 1 and 2 (each within the scatter of the next); then compound 3.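

At the aromatic carbon of the shared core, putting 4-(5-methyl-1,3-thiazol-2-yl)-2-oxopyrrolidin-1-yl in place of the benzo-fused lactam gives a 2.5-fold higher number from compound 2 to compound 3 (0.40 log units; beyond the scatter) in this assay and so means lower toxicity in this test, showing that the group at this position can shift the reading, which compound 1 and compound 2 on their own did not show. The sharper comparison lies on the saturated ring carbon of the pyrrolidinone, where 5-methyl-1,3-thiazol-2-yl in place of 5-fluoropyridin-2-yl gives a 2.5-fold higher number from compound 1 to compound 3 (0.40 log units; beyond the scatter) while the lactam stays the same, so the small aromatic ring carried by the pyrrolidinone matters to this reading and not the pyrrolidinone alone. No measurement at hand offers a reason for either step.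

The three compounds cannot separate the part played by the methyl group from that of the thiazole ring itself, and a plain 1,3-thiazol-2-yl at the same carbon would be needed to tell them apart. From the compounds shown here alone, how a phenyl ring or a simple methyl group on that saturated ring carbon would read also stays open.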